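Swapping the Aryl Group on the Triazole Nitrogen

The source may report more compounds than this note shows. Statements on the series, on what has been measured and on what is new or still open speak of the compounds shown alone.

Three hydroxamic acids built on one shared core have been tested in a functional assay on MGC-803 cells (Homo sapiens) for antiproliferative activity, read by MTT assay, with a stated time of 72 h; on this read-out higher numbers stand for weaker inhibition and lower numbers for stronger inhibition. Compound 1 `Cc1cccc(-c2nc(CNc3ccc(C(=O)NO)cc3)n(-c3ccccc3)n2)c1` gives 8710 nM. Compound 2 `Cc1ccc(-c2nc(CNc3ccc(C(=O)NO)cc3)n(-c3ccccc3)n2)cc1` reaches only a limit of the assay, > 20000 nM, one of the values sitting at the limit of > 20000 nM in this assay, at which 1 of the 3 values shown sits. The step of an at least 2.2-fold higher number from compound 1 to compound 2 (0.36 log units; beyond the scatter) is thus a weakening beyond the usual scatter. Compound 3 `Cc1cccc(-n2nc(-c3ccccc3)nc2CNc2ccc(C(=O)NO)cc2)c1` gives 13200 nM, and its gap to compound 1 lies within the scatter, so the two cannot be told apart. Compound 4 `O=C(NO)c1ccc(NCc2nc(-c3ccccc3)nn2-c2ccc(F)cc2)cc1` differs from compound 3 by 4-fluorophenyl in place of 3-methylphenyl on an aromatic nitrogen. Within the data shown here, the single measured step concerns the group on the aromatic carbon, not the one on the aromatic nitrogen, so it bears only loosely here; it showed that exchanging 3-methylphenyl for 4-methylphenyl weakened inhibition modestly. Fluorine is a different group again, so no shift beyond the scatter is expected, with the estimated change being a 1.1-fold higher number from compound 3 to compound 4 (0.06 log units; within the scatter). Compound 4 is therefore expected to give about 15000 nM, within a range of 6000 nM to 40000 nM.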

Compound 4, half-maximal inhibitory concentration: 10500 nM
Compound 4: middle estimate off by 1.4-fold (0.15 log units), on the high side; the range from low to high includes it.
By their numbers in this assay, from the lowest: compounds 1, 4 and 3 (each within the scatter of the next). At a limit, above all of these: compound 2.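

On the aromatic nitrogen of the shared core, 4-fluorophenyl stands in for 3-methylphenyl without a change that can be read in this assay, with a 1.3-fold lower number from compound 3 to compound 4 (0.10 log units; within the scatter). This swap alters two things at once, the group on the phenyl ring and where that group sits, and together they leave the result inside the scatter. Nothing measured here offers a reason why these two groups read alike.

Going by these compounds, whether the identity of the group or its place on the ring matters more at this nitrogen stays open, and a 3-fluorophenyl or 4-methylphenyl there would separate the two. Also open, on these data alone, is how a phenyl ring carrying an amine, a carboxylic acid or a longer chain would behave at this position.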